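Swapping trifluoromethyl for methoxymethyl on a slowly cleared compound

The source may hold more compounds than are shown below. What is called first, only, known or untested is meant among the compounds shown, and "the series" means these compounds.

Compound 1 `Cc1cc(Nc2ccc(S(F)(F)(F)(F)F)cc2)n2nc(C(F)(F)F)nc2n1` is tested in an in vitro ADME assay on microsomes from liver (Mus musculus) for metabolic stability; a lower number here means slower removal, a higher number faster removal of the compound. There compound 1 gives < 6 mL.min-1.g-1, which is a limit of the assay and not a number.

Compound 4 `COCc1nc2nc(C)cc(Nc3ccc(S(F)(F)(F)(F)F)cc3)n2n1` keeps the rest of compound 1 and changes one group: methoxymethyl in place of trifluoromethyl on an aromatic carbon. In words, methoxymethyl stands in place of trifluoromethyl on an aromatic carbon.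

Within the data shown here, no measured pair isolates this change, so the guidance is loose. Compound 2 `CCOc1nc2nc(C)cc(Nc3ccc(C(F)(F)F)cc3)n2n1` gives 14.4 mL.min-1.g-1 and compound 3 `CCc1nc2nc(C)cc(Nc3ccc(Cl)cc3)n2n1` gives 63.1 mL.min-1.g-1, and neither carries trifluoromethyl at that place, though they differ elsewhere too. On those values, a rise beyond the usual scatter is expected, and the estimated step is an at least 2.3-fold higher number from compound 1 to compound 4 (0.36 log units; beyond the scatter).

For compound 4 the estimated value is 14 mL.min-1.g-1, with an expected range of 6 mL.min-1.g-1 to 35 mL.min-1.g-1.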

Compound 4, intrinsic clearance in microsomes: 14.3 mL.min-1.g-1
Compound 4: the middle estimate sits 1.0-fold (0.01 log units) below what was measured; the range from low to high includes it.
By their numbers in this assay, from the lowest: compounds 4 and 2 (each within the scatter of the next); then compound 3. At a limit, below all of these: compound 1.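

In this assay, methoxymethyl in place of trifluoromethyl on this aromatic carbon gives an at least 2.3-fold higher number from compound 1 to compound 4 (0.37 log units; beyond the scatter), the first step shown that isolates this position. Compound 1 gives < 6 mL.min-1.g-1, which is a limit and not a number. The full size of the step stays unknown because one of its two ends is such a limit: the limit of < 6 mL.min-1.g-1 in this assay, at which 1 of the 4 values shown sits.

The compounds shown leave open what an amine, a carboxylic acid or a longer chain such as methoxyethyl would give at this place. They also leave open whether the same swap gives a similar step elsewhere in the series.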